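Cytotoxicity of a benzyloxy analogue in the shared core

The compounds below may be only part of what the source reports. "The series", "measured", "known", "first", "only" and "open" are said of these compounds alone.

Compound 1 `Nc1nc(NC2CC2)c2ncn(/C=C3/CC3(CO)CO)c2n1` is the reference point. In an ADME assay on Akata cells (Homo sapiens) for cytotoxicity, with a stated time of 7 days (on this read-out higher numbers stand for lower toxicity in this test and lower numbers for higher toxicity in this test), compound 1 gives only a limit of the assay, > 20000 nM, not a number. Compound 2 `CCCNc1nc(N)nc2c1ncn2/C=C1/CC1(CO)CO` likewise gives only a limit, > 24000 nM. Compound 3 `Nc1nc(NC2CCCC2)c2ncn(/C=C3/CC3(CO)CO)c2n1` also sits at a limit, > 20000 nM. The step that the two limits leave unreadable from compound 1 to compound 2 cannot be read, and the same holds for a step that the two limits leave unreadable from compound 1 to compound 3 and a step that the two limits leave unreadable from compound 2 to compound 3: two of the three values rest at the limit of > 20000 nM in this assay, at which 2 of the 3 values shown sit, and the third at the limit of > 24000 nM in this assay, at which 1 of the 3 values shown sits, so no size or direction can be taken from any of them.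

Compound 4 `Nc1nc(OCc2ccccc2)c2ncn(/C=C3/CC3(CO)CO)c2n1` differs from compound 1 by the change (benzyloxy in place of cyclopropylamino on an aromatic carbon). For the measured compounds named here, none of the measured steps bears on this change in a readable way, since every value in this assay is a limit. Compound 4 is therefore expected to behave like its three relatives and to reach the limit rather than a number, so the step of a number no higher from compound 1 to compound 4 (the limit leaves the size open) is estimated to be none beyond the scatter. The estimate for compound 4 is 20000 nM, with a range from 7000 nM to 50000 nM.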

Compound 4, half-maximal cytotoxic concentration: > 20000 nM
Compound 4 gave a limit, no number (the forecaster's own chance of this, stated with the estimate: 70%); the middle value lies on the limit itself.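

In this assay compound 4 gives > 20000 nM as a limit of the assay, not a number. For the compounds shown here, no step from compound 1, compound 2 or compound 3 to compound 4 can be read: the limit of > 20000 nM in this assay, at which 3 of the 4 values shown sit. The compounds shown leave open whether benzyloxy, cyclopropylamino, propylamino or cyclopentylamino on the shared core makes any difference in this assay at all.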